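This account rests on a few compounds, and the source may have more. Where it says the series, first, only, none or still open, it means among the compounds named here.

Working notes on the series. In a functional assay on WI-38 VA13 cells (Homo sapiens) for cytotoxicity (a higher number here means that more compound is needed for the effect, a lower number that less compound is needed), compound 1 `O=C(Nc1ccc2nc(NC(=O)C3CCCCC3)sc2c1)c1ccccc1Oc1ccccc1` gives 0.1 ug/mL. Compound 2 `O=C(Nc1ccc2nc(NC(=O)C3CCCCC3)sc2c1)c1cccc(F)c1` gives 0.64 ug/mL, the higher of the two values that are actual numbers. Compound 3 `O=C(Nc1ccc2nc(NC(=O)C3CCCCC3)sc2c1)c1cccc(Oc2ccccc2)c1` reads > 4 ug/mL, which is a limit of the assay and not a number.

The next compound is compound 4 `O=C(Nc1ccc2nc(NC(=O)C3CCCCC3)sc2c1)c1ccc(Cl)cc1Cl`, still unmeasured in this assay. Its change is 2,4-dichlorophenyl in place of 3-fluorophenyl on a carbonyl carbon.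

Going by the values given here, only one measured step bears on this change: an at least 6.2-fold higher number from compound 2 to compound 3 (0.79 log units; beyond the scatter), with phenoxy in place of fluoro on an aromatic carbon. That step is beyond the scatter, but it gives no reliable direction for compound 4. Compound 1 also carries a phenoxy group, and it gives the lower value of 0.1 ug/mL. With numbers on both sides of compound 2, no step beyond the scatter is expected in this assay, though the uncertainty is wide. The expected change is a 1.1-fold lower number from compound 2 to compound 4 (0.03 log units; within the scatter). The estimate for compound 4 is 0.6 ug/mL, with an expected range from 0.15 ug/mL to 2.5 ug/mL.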

Compound 4, half-maximal effective concentration: > 4 ug/mL
Compound 4: a limit, no number (the forecaster's own chance of this, stated with the estimate: 15%); middle value at least 6.6-fold (0.82 log units) from the limit.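

In this assay, the step at this position is an at least 6.2-fold higher number from compound 2 to compound 4 (0.79 log units; beyond the scatter), so a replacement on the carbonyl carbon that carries no phenoxy group also moves the number upward. Compound 4 reads > 4 ug/mL, which is a limit of the assay and not a number, and compound 3 sits at the same limit, so neither the full size of the step nor any order between these two compounds can be read: the limit of > 4 ug/mL in this assay, at which 2 of the 4 values shown sit. The upward direction therefore holds for both replacements of 3-fluorophenyl measured in single steps, but compound 1, at 0.1 ug/mL, goes against any general rule for the aryl group.

On these data alone, it remains open whether one chlorine alone would give the same step as the two in 2,4-dichlorophenyl. As far as these compounds go, the response of this position to an amine or a carboxylic acid on the ring also remains open.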